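Changing the Ring at the End of the Chain

This account rests on a few compounds, and the source may have more. Where it says the series, first, only, none or still open, it means among the compounds named here.

Three measured compounds share one core and differ only in the small ring that sits on a saturated chain carbon bound to an oxygen on an aromatic ring. Compound 1 `CCC(C)(C)Cc1c[nH]c(CCc2ccc(-c3ccccc3OCc3ncn[nH]3)cc2)n1` carries that ring with a hydrogen, compound 2 `CCC(C)(C)Cc1c[nH]c(CCc2ccc(-c3ccccc3OCc3nc(N)n[nH]3)cc2)n1` carries an amino group on an aromatic carbon of it, and compound 3 `CCC(C)(C)Cc1c[nH]c(CCc2ccc(-c3ccccc3OCc3nc(C(F)(F)F)n[nH]3)cc2)n1` carries a trifluoromethyl there. In an assay on isolated protein for binding affinity to Bombesin receptor subtype-3 (Homo sapiens) (a higher number here means a weaker inhibitor, a lower number a stronger inhibitor), compound 1 gives 22 nM, compound 2 gives 27 nM, and compound 3 gives 127 nM. Compound 3 therefore stands at the highest of the three numbers and is the weakest binder of the set: a 5.8-fold higher number from compound 1 to compound 3 (0.76 log units; beyond the scatter) and a 4.7-fold higher number from compound 2 to compound 3 (0.67 log units; beyond the scatter), whereas a 1.2-fold higher number from compound 1 to compound 2 (0.09 log units; within the scatter).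

Compound 4 `CCC(C)(C)Cc1c[nH]c(CCc2ccc(-c3ccccc3OCc3nc(=O)[nH][nH]3)cc2)n1` exchanges the whole end ring: a group of 6 heavy atoms (2 carbon, 3 nitrogen, 1 oxygen; one five-membered aromatic ring with 3 hetero atoms) in place of a group of 9 heavy atoms (3 carbon, 3 nitrogen, 3 fluorine; one five-membered aromatic ring with 3 hetero atoms), on a saturated chain carbon bound to an oxygen on an aromatic ring. Among the measured compounds shown here, no measured step tests the entering ring itself. The two steps that end at compound 3 both show the trifluoromethyl-bearing ring giving the weaker number, so taking it away is expected to recover part of that loss, while the untested new ring keeps the range wide. For compound 4 in this assay a value of 45 nM is expected, between 15 nM and 140 nM. That estimate corresponds to an expected 2.8-fold lower number from compound 3 to compound 4 (0.45 log units; beyond the scatter).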

Compound 4, half-maximal inhibitory concentration: 31 nM
The estimate for compound 4 lay 1.5-fold (0.16 log units) above the measured number; measured number inside the range.
By their numbers in this assay, from the lowest: compounds 1, 2 and 4 (each within the scatter of the next); then compound 3.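

Compound 4 shows that the weak number of compound 3 is not a fixed cost of changing the ring on this saturated chain carbon: in this assay, exchanging the 3-(trifluoromethyl)-1H-1,2,4-triazol-5-yl group for a ring with a double-bonded oxygen gives a clear gain (a 4.1-fold lower number from compound 3 to compound 4 (0.61 log units; beyond the scatter)). The new ring also sits level with the two better rings (a 1.1-fold higher number from compound 2 to compound 4 (0.06 log units; within the scatter); a 1.4-fold higher number from compound 1 to compound 4 (0.15 log units; within the scatter)), so three different end rings now give matching numbers, and compound 3 is the only one of the four that goes against this. Nothing available here explains why the trifluoromethyl-bearing ring stands apart from the others.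

The compounds shown leave open whether the loss belongs to trifluoromethyl in particular or would also appear with a methyl or an ethyl on the same aromatic carbon. They also leave open how far the ring itself matters, which a carboxylic acid or a simple amide in place of the whole ring could begin to test.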